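The source may hold more compounds than are shown below. What is called first, only, known or untested is meant among the compounds shown, and "the series" means these compounds.

Measured so far:
- Compound 1 `COc1ccc(/C=C/C(=O)Nc2cc(C(=O)c3cc(OC)c(OC)c(OC)c3)cc(OC)c2OC)cc1N`: 7700 nM
- Compound 2 `C#CCOc1cccc(/C=C/C(=O)Nc2cc(C(=O)c3cc(OC)c(OC)c(OC)c3)cc(OC)c2OC)c1`: 8100 nM

Both compounds were tested in a functional assay on HT-29 cells (Homo sapiens) for cytotoxicity, read by MTT assay, with a stated time of 72 h; on this read-out higher numbers stand for weaker inhibition and lower numbers for stronger inhibition. On the numbers shown, compound 2 cannot be told apart from compound 1, the only other compound measured, since a 1.1-fold higher number from compound 1 to compound 2 (0.02 log units; within the scatter) lies within the usual scatter. Both share a large core and differ only in the aryl group that sits at the far end of the double-bonded chain.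

Compound 3 `COc1cc(C(=O)c2cc(OC)c(OC)c(OC)c2)cc(NC(=O)/C=C/c2ccc(C(F)(F)F)cc2)c1OC` has not yet been measured. It differs from compound 2 in exactly that same position: 4-(trifluoromethyl)phenyl in place of 3-(propargyloxy)phenyl on a double-bonded chain carbon bound to a double-bonded chain carbon.

Going by the values given here, the only measured step that bears on this change is the one from compound 1 to compound 2, which swapped one aryl group for another at the same place on the chain and produced no step beyond the scatter. With a single step of that kind to go on, no reason is visible to expect a shift in this assay beyond the scatter in either direction.

Compound 3 is therefore expected to give about 8000 nM in this assay, within a range of 2500 nM to 25000 nM, which means an expected step of a 1.0-fold lower number from compound 2 to compound 3 (0.01 log units; within the scatter).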

Compound 3, half-maximal inhibitory concentration: 1900 nM
The estimate for compound 3 lay 4.2-fold (0.62 log units) above the measured number; measured number outside the range, below it.
By their numbers in this assay, from the lowest: compound 3; then compounds 1 and 2 (each within the scatter of the next).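

In this assay the group on a double-bonded chain carbon bound to a double-bonded chain carbon now proves able to shift the number: 4-(trifluoromethyl)phenyl gives a lower value than either group it replaces (a 4.3-fold lower number from compound 2 to compound 3 (0.63 log units; beyond the scatter); a 4.1-fold lower number from compound 1 to compound 3 (0.61 log units; beyond the scatter)). The earlier swap between the other two groups stayed within the scatter (a 1.1-fold higher number from compound 1 to compound 2 (0.02 log units; within the scatter)), so that step alone could not show this place responding to any change, whereas these two modest steps, both beyond the scatter, show that it can, at least for this group on the shared core. Nothing shown here explains why this group gives the lower number.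

Whether that lower number belongs to the trifluoromethyl group itself stays open, as the compounds shown include no phenyl ring at this place that carries a nitrile, a chlorine atom or no added group at all. Also open, going by these compounds, is how this assay would respond to a carboxylic acid on that ring, a group unlike any of the three seen so far.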